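Swapping chloro for fluoro on an aromatic ring

A few compounds are considered here, and "the series" means these few. Any claim that something is new, unique, unknown or untested is made for them only; others in the source may bear on it.

Measured so far:
compound 1, `Fc1ccc(N2N=NCC2c2ccncc2)cc1` — 203 mg/kg
compound 2, `c1ccc(-n2nncc2-c2ccncc2)cc1` — 73.7 mg/kg
compound 3, `Clc1ccc(-n2nncc2-c2cccnc2)cc1` — 27 mg/kg

These three compounds have been tested in a functional assay on the whole organism with Mus musculus as the target; on this read-out lower numbers stand for an effect already at smaller amounts and higher numbers for an effect only at larger amounts of compound. Compound 3 holds the lowest number of the three; compound 2 comes nearest with a number beyond the scatter above it, and compound 1 lies furthest away. Compound 2 and compound 3 share the same core, and compound 3 differs from compound 2 only in the chloro and in where the nitrogen sits in the pyridine ring; compound 1 has a different core, so neither pair forms a single clean step.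

The compound not yet measured is compound 4, `Fc1ccc(-n2nncc2-c2cccnc2)cc1`. Relative to compound 3 the change is fluoro in place of chloro on an aromatic carbon. Going by the values given here, no measured pair in this set shows what such a halogen swap does here, so the expectation rests on the general smallness of the change. A modest step from compound 3 to compound 4, toward a somewhat higher number, is expected; it may well fall within the scatter. Compound 4 is therefore estimated at 40 mg/kg, with a range from 18 mg/kg to 90 mg/kg, and the expected step is a 1.5-fold higher number from compound 3 to compound 4 (0.17 log units; within the scatter).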

Compound 4, dose for half-maximal effect: 47.9 mg/kg
The estimate for compound 4 lay 1.2-fold (0.08 log units) below the measured number; low and high end bracket the measured number.
By their numbers in this assay, from the lowest: compounds 3, 4 and 2 (each within the scatter of the next, the first and the last beyond it); then compound 1.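

In this assay, going by these compounds alone, fluoro in place of chloro on the aromatic carbon gives a 1.8-fold higher number from compound 3 to compound 4 (0.25 log units; within the scatter) and is the first direct reading of a halogen swap in this set. On this read-out, compound 3 and compound 4 cannot be told apart, so at this position, para to a large group, the two halogens are not separated by the whole-animal result. No measured information is available to explain this outcome.

The compounds shown leave open what a group other than a halogen, such as an amine, a methoxy group or a nitrile, would do at this same place. Within the data shown here, they also leave open whether the same swap would read alike on a different core, since this is the only such pair here.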